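A few compounds are considered here, and "the series" means these few. Any claim that something is new, unique, unknown or untested is made for them only; others in the source may bear on it.

Measured so far in an assay on cells for inhibition of cytochrome P450 11B1, mitochondrial (Homo sapiens); on this read-out higher numbers stand for weaker inhibition and lower numbers for stronger inhibition:
compound 1 `CC(C)CC1n2cncc2CN(CC2CC2)S1(=O)=O`, 122 nM
compound 2 `CC(C)CC1n2cncc2CN(Cc2ccc(OC(F)(F)F)cc2)S1(=O)=O`, 544 nM
compound 3 `C[C@@H](c1ccc(Cl)cc1)N1Cc2cncn2C(CC2(C)COC2)S1(=O)=O`, 340 nM

Compound 2 gives the highest number of the three in this assay. The gap to compound 3 lies within the scatter, so the two cannot be told apart; the gap to compound 1 lies beyond it, compound 1 sitting clearly lower.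

Compound 4 `CC(C)CC1n2cncc2CN(Cc2ccccc2)S1(=O)=O` differs from compound 2 in one place: hydrogen in place of trifluoromethoxy on an aromatic carbon. Going by the values given here, no measured pair in this set shows the same change, so its size is not known from the data. The step from compound 2 to compound 4 is expected to be small, toward a lower number, and possibly not beyond the scatter; the expected step is a 1.6-fold lower number from compound 2 to compound 4 (0.19 log units; within the scatter). Compound 4 is accordingly estimated at 350 nM, with a range from 120 nM to 1000 nM.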

Compound 4, half-maximal inhibitory concentration: 103 nM
Compound 4: the middle estimate sits 3.4-fold (0.53 log units) above what was measured, and the stated range ends above it.
By their numbers in this assay, from the lowest: compounds 4 and 1 (each within the scatter of the next); then compounds 3 and 2 (each within the scatter of the next).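

In this assay, hydrogen in place of trifluoromethoxy on the aromatic carbon para to a large group gives a 5.3-fold lower number from compound 2 to compound 4 (0.72 log units; beyond the scatter) and shows that the series is sensitive to this change at this position. Phenyl in place of cyclopropyl on the saturated chain carbon bound to the sulfonamide nitrogen gives a 1.2-fold lower number from compound 1 to compound 4 (0.07 log units; within the scatter) and leaves the two compounds indistinguishable. Nothing on hand explains either step.

Open, from the compounds shown here alone, is whether chlorine or a methoxy group on that same aromatic carbon would read like compound 4 or like compound 2. Also open, going by these compounds, is whether the step would hold with a different chain on the shared core.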